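From 1H-pyrazol-4-yl to 2-fluorophenyl: working notes on the series

This account rests on a few compounds, and the source may have more. Where it says the series, first, only, none or still open, it means among the compounds named here.

Among the compounds with values here, in a functional assay on NCI-H1993 cells (Homo sapiens) for inhibition, read by CCK-8 assay, with a stated time of 72 h (a lower number here means a stronger inhibitor, a higher number a weaker inhibitor), compound 2 `c1cnc2ccc(Cn3cnc4ncc(-c5cn[nH]c5)nc43)cc2c1` gives 2890 nM, the only number available so far, so its rank cannot be judged. Compound 1 `CCC(c1cc2cccnc2cc1F)n1cnc2ncc(-c3cnn(CCO)c3)nc21` stands as "not determined" (no result reported), and compound 3 `CCC(c1cc2cccnc2cc1F)n1cnc2ncc(-c3cnc4ccccc4c3)nc21` stands as "not determined" (no result reported). Compound 4 `Fc1ccccc1-c1cnc2ncn(Cc3ccc4ncccc4c3)c2n1` carries 2-fluorophenyl in place of the 1H-pyrazol-4-yl of compound 2, on an aromatic carbon (2-fluorophenyl in place of 1H-pyrazol-4-yl on an aromatic carbon). Within the data shown here, no measured step bears on this change, so any expectation remains loose. A moderate weakening in this assay is expected, estimated as a 2.1-fold higher number from compound 2 to compound 4 (0.32 log units; beyond the scatter), and a result within the usual scatter would not surprise. For compound 4 the estimated value is 6000 nM, with an expected range of 1800 nM to 20000 nM.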

Compound 4, half-maximal inhibitory concentration: > 10000 nM
Compound 4: a limit, no number (the forecaster's own chance of this, stated with the estimate: 25%); at least 1.6-fold (0.22 log units) between middle value and limit.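

In this assay compound 4 gives > 10000 nM, which is a limit of the assay and not a number. Within the data shown here, this is the first reading of a change at this aromatic carbon: 2-fluorophenyl in place of 1H-pyrazol-4-yl gives an at least 3.4-fold higher number from compound 2 to compound 4 (0.53 log units; beyond the scatter), beyond the scatter. The step has a floor but no measured size: the limit of > 10000 nM in this assay, at which 1 of the 4 values shown sits.

Open, from the compounds shown here alone, is whether an unsubstituted phenyl, a pyridine or a 1-methylpyrazole at this carbon would stay closer to compound 2. Also open, going by these compounds, is whether an amine on the 2-fluorophenyl ring would change the reading.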